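The source may hold more compounds than are shown below. What is called first, only, known or untested is meant among the compounds shown, and "the series" means these compounds.

For the measured compounds named here, compound 2, with the structure `CCOC(=O)c1c(-c2cc3ccccc3oc2=O)nn(-c2cccc(Cl)c2)c1C(=O)OCC`, stands lowest of the two numbers so far in a functional assay on HeLa cells (Homo sapiens) for cytotoxicity, read by MTT assay, with a stated time of 48 h; on this read-out higher numbers stand for weaker inhibition and lower numbers for stronger inhibition: in this assay compound 2 gives 22000 nM. Going by the values given here, its only neighbour is compound 1, with the structure `CCOC(=O)c1c(-c2cc3ccccc3oc2=O)nn(-c2ccccc2)c1C(=O)OCC`, which in this assay gives 100000 nM; the step of a 4.5-fold lower number from compound 1 to compound 2 (0.66 log units; beyond the scatter) came from a chloro in place of hydrogen on an aromatic carbon.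

Compound 3, with the structure `CCOC(=O)c1c(-c2cc3ccc(OCC=C(C)C)cc3oc2=O)nn(-c2cccc(Cl)c2)c1C(=O)OCC`, differs from compound 2 in one place: (3-methylbut-2-en-1-yl)oxy in place of hydrogen on an aromatic carbon. Among the compounds with values here, this change sits on the fused two-ring part of the shared core, not on the ring that carried the chloro, so the one measured step does not bear on it directly. Within the data shown here, there is no measured step for a (3-methylbut-2-en-1-yl)oxy group entering anywhere, and no measured step at all on this ring. With nothing to lean on, the expected step of a 1.1-fold lower number from compound 2 to compound 3 (0.04 log units; within the scatter) is none beyond the scatter. Compound 3 is therefore estimated to give 20000 nM in this assay, within a range from 6000 nM to 70000 nM.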

Compound 3, half-maximal inhibitory concentration: 110000 nM
Compound 3: middle estimate off by 5.5-fold (0.74 log units), on the low side; measured number above the stated range.
By their numbers in this assay, from the lowest: compound 2; then compounds 1 and 3 (each within the scatter of the next).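

For the compounds shown here, this is the first measured change on the fused two-ring part of the shared core, and in this assay the entry of (3-methylbut-2-en-1-yl)oxy gives a 5.0-fold higher number from compound 2 to compound 3 (0.70 log units; beyond the scatter). That step is beyond the scatter, so this aromatic carbon, meta to a fused ring and para to a fused ring, is not a place where the number stays put when this chain enters, and it runs in the opposite direction to the chloro step, a 4.5-fold lower number from compound 1 to compound 2 (0.66 log units; beyond the scatter). Nothing available explains why the number rises at this position.

From the compounds shown here alone, whether the rise belongs to this particular chain or would also follow from a hydroxyl, a methoxy or an amine on the same aromatic carbon stays open. So does whether (3-methylbut-2-en-1-yl)oxy would move the number the same way on the core of compound 1, which lacks the chloro, or on another carbon of the same ring.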